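A few compounds are considered here, and "the series" means these few. Any claim that something is new, unique, unknown or untested is made for them only; others in the source may bear on it.

Series notes. Compound 1 `Cc1ccc(Cn2cc(CNC(=O)c3cnc(Nc4ccc(C#N)cc4)cc3Oc3c(C)cc(C)cc3C)nn2)cc1` and compound 2 `COC(=O)Cn1cc(CNC(=O)c2cnc(Nc3ccc(C#N)cc3)cc2Oc2c(C)cc(C)cc2C)nn1` share one core and differ only in the group on the saturated chain carbon bound to an aromatic nitrogen. In an ADME assay on MT4 cells (Homo sapiens) for cytotoxicity, read by MTT assay, with a stated time of 5 days (on this read-out higher numbers stand for lower toxicity in this test and lower numbers for higher toxicity in this test), compound 1 gives 165000 nM. In this assay, within the data shown here, compound 2 gives 13800 nM, the lowest of the two numbers so far, and the one measured step, a 12-fold lower number from compound 1 to compound 2 (1.08 log units; beyond the scatter), is the only comparison available. Compound 3 `Cc1cc(C)c(Oc2cc(Nc3ccc(C#N)cc3)ncc2C(=O)NCc2cn(Cc3cccc(C#N)c3)nn2)c(C)c1` is still to be measured in this assay. It differs from compound 2 at the same place: 3-cyanophenyl in place of methoxycarbonyl on a saturated chain carbon bound to an aromatic nitrogen. Among the measured compounds shown here, the single step that bears on this change is a 12-fold lower number from compound 1 to compound 2 (1.08 log units; beyond the scatter), which ran from an aryl group on that carbon to methoxycarbonyl and was large. Compound 3 reverses that direction by putting an aryl group back, though this one carries a nitrile rather than a methyl, so a step upward toward the number of compound 1 is expected. The expected step from compound 2 is a 5.8-fold higher number from compound 2 to compound 3 (0.76 log units; beyond the scatter). Compound 3 is therefore estimated at 80000 nM in this assay, with a range from 25000 nM to 200000 nM.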

Compound 3, half-maximal cytotoxic concentration: >= 129000 nM
Compound 3: no number, only a limit; the forecaster's own chance of this, stated with the estimate: 15%; at least 1.6-fold (0.20 log units) between middle value and limit.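

In this assay, replacing methoxycarbonyl with 3-cyanophenyl on the saturated chain carbon bound to an aromatic nitrogen gives an at least 9.3-fold higher number from compound 2 to compound 3 (0.97 log units; beyond the scatter), a step beyond the scatter that points to lower toxicity in this test. This adds a second aryl group to the comparison: 4-methylphenyl in compound 1 and 3-cyanophenyl in compound 3 both stand on the higher side of compound 2, so among the three compounds shown, the low number goes with methoxycarbonyl alone. For compound 3 the reading is a limit and not a number, so its step to compound 1 cannot be read: the limit of >= 129000 nM in this assay, at which 1 of the 3 values shown sits.

The compounds shown leave open whether the low number of compound 2 goes with the methoxycarbonyl group itself or with the absence of an aryl group, a question that a carboxylic acid, an amine or a plain longer alkyl chain on that carbon would help to separate. They also leave open whether 3-cyanophenyl and 4-methylphenyl differ at all in this assay, and whether the position of the nitrile on the aryl ring has any bearing on the number.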